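The source may report more compounds than this note shows. Statements on the series, on what has been measured and on what is new or still open speak of the compounds shown alone.

Compound 1, `Cc1ccccc1-c1noc(-c2ccc(C3CCCCC3)cc2)n1`, was tested in a functional assay on CHO cells with sphingosine 1-phosphate receptor 4 (Homo sapiens) as the target, read by GTPgammaS binding; a lower number here means that less compound is needed, a higher number that more compound is needed for the effect. In this assay compound 1 gives > 10000 nM, which is a limit of the assay and not a number. Compound 2, `Cc1cc(CCC(=O)O)ccc1-c1noc(-c2ccc(OC(C)C)c(Br)c2)n1`, also returns only a limit in this assay, namely > 10000 nM. Compound 3, `Cc1cc(CCC(=O)O)ccc1-c1noc(-c2ccc(OC(C)C(F)(F)F)c(C#N)c2)n1`, likewise reaches no number in this assay, only the limit > 10000 nM. For the measured compounds named here, all three values thus rest at the same point, (the limit of > 10000 nM in this assay, at which 3 of the 3 values shown sit), so no pair of measured compounds yields a step of known size or direction. The unmeasured compound 4, `Cc1cc(CCC(=O)O)ccc1-c1noc(-c2ccc(C3CCCCC3)cc2)n1`, differs from compound 1 by 2-carboxyethyl in place of hydrogen on an aromatic carbon. Going by the values given here, because every value shown sits at the limit of > 10000 nM in this assay, at which 3 of the 3 values shown sit, there is no measured step from which a direction could be taken, and compound 2 and compound 3, which already carry the 2-carboxyethyl group, add no number. The step one expects is a step that the limit leaves unreadable from compound 1 to compound 4, nothing beyond the scatter. Compound 4 is accordingly estimated at 15000 nM, between 5000 nM and 50000 nM, with a strong chance that this assay again reports only a limit.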

Compound 4, half-maximal effective concentration: > 10000 nM
Compound 4 was reported as a limit (the forecaster's own chance of this, stated with the estimate: 80%); the middle value is on the limit's open side.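

For the compounds shown here, compound 1 and compound 4 both rest at a limit, so no step between them can be read: (the limit of > 10000 nM in this assay, at which 4 of the 4 values shown sit). The compounds shown leave open whether the 2-carboxyethyl group changes anything in this assay and what change to the shared core would give a measurable value there.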